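Triazolyl-aryl variation on a spiro-oxindole series: HUVEC antiproliferation

This account rests on a few compounds, and the source may have more. Where it says the series, first, only, none or still open, it means among the compounds named here.

Measured so far in an ADME assay on HUVEC cells (Homo sapiens) for antiproliferative activity, read by MTT assay, with a stated time of 48 h; on this read-out higher numbers stand for weaker inhibition and lower numbers for stronger inhibition:
compound 1, `Cc1ccccc1-n1nncc1CN1C(=O)C2(C(C#N)=C(N)Oc3c2c2nc4ccccc4nc2c2ccccc32)c2ccccc21`, gives > 50000 nM, a limit of the assay.
compound 2, `N#CC1=C(N)Oc2c(c3nc4ccccc4nc3c3ccccc23)C12C(=O)N(Cc1cnnn1-c1ccc(F)cc1)c1ccccc12`, gives > 50000 nM, a limit of the assay.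
compound 3, `N#CC1=C(N)Oc2c(c3nc4ccccc4nc3c3ccccc23)C12C(=O)N(Cc1cnnn1-c1cccc(Cl)c1)c1ccccc12`, gives > 50000 nM, a limit of the assay.

Compound 3 therefore stands at the assay limit, as do the other two members; no ranking among them is possible, since the limit of > 50000 nM in this assay, at which 3 of the 3 values shown sit, covers every value shown. The steps a step that the two limits leave unreadable from compound 1 to compound 2, a step that the two limits leave unreadable from compound 1 to compound 3 and a step that the two limits leave unreadable from compound 2 to compound 3 are all unreadable for the same reason.

Compound 4, `N#CC1=C(N)Oc2c(c3nc4ccccc4nc3c3ccccc23)C12C(=O)N(Cc1cnnn1-c1ccccc1Br)c1ccccc12`, differs from compound 3 by 2-bromophenyl in place of 3-chlorophenyl on an aromatic nitrogen. For the measured compounds named here, the three measured steps bear on the same position on the aromatic nitrogen and none of them resolved a change, so they give no direction for this step. The expected step that the limit leaves unreadable from compound 3 to compound 4 is accordingly none beyond the scatter, with the outcome most likely again a limit. Compound 4 is estimated at 60000 nM in this assay, with a range from 20000 nM to 200000 nM.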

Compound 4, half-maximal inhibitory concentration: > 50000 nM
Compound 4: no number, only a limit (the forecaster's own chance of this, stated with the estimate: 85%); the middle value lies beyond the limit too.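

In this assay, for the compounds shown here, no step involving compound 4 can be read, and compound 1, compound 2 and compound 3 offer no comparison either, all sharing one limit: the limit of > 50000 nM in this assay, at which 4 of the 4 values shown sit. The compounds shown leave open whether any aryl group on this aromatic nitrogen gives a measurable value.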